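This account rests on a few compounds, and the source may have more. Where it says the series, first, only, none or still open, it means among the compounds named here.

Working notes, sulfonyl series. Compound 3 `COc1ccc(-c2cc(=O)c3c(OC)cc(OC)cc3n2S(=O)(=O)c2c(F)c(F)c(F)c(F)c2F)cc1` holds the lowest number of the three measured in a functional assay on SUP-B15 cells (Homo sapiens) for antiproliferative activity, with a stated time of 72 h (a lower number here means that less compound is needed, a higher number that more compound is needed for the effect), giving 4100 nM. Compound 1 `C=CCNC(=O)n1c(-c2ccc(OC)cc2)cc(=O)c2c(OC)cc(OC)cc21` is nearest in this assay with 16000 nM, and compound 2 `COc1ccc(-c2cc(=O)c3c(OC)cc(OC)cc3n2S(=O)(=O)c2ccc([N+](=O)[O-])cc2)cc1` sits furthest with 17100 nM. Within the data shown here, the only step on the sulfonyl sulfur so far is a 4.2-fold lower number from compound 2 to compound 3 (0.62 log units; beyond the scatter). Compound 4 `COc1ccc(-c2cc(=O)c3c(OC)cc(OC)cc3n2S(=O)(=O)Cc2ccccc2)cc1` is the next member; the change is benzyl in place of 2,3,4,5,6-pentafluorophenyl on a sulfonyl sulfur. Among the measured compounds shown here, only that one step bears on this position, and it shows the pentafluorophenyl group paired with the lowest number, so removing it is expected to move the number back up toward where compound 1 and compound 2 stand. The expected step is a 2.2-fold higher number from compound 3 to compound 4 (0.34 log units; beyond the scatter). Compound 4 is therefore estimated at 9000 nM, with a range from 3000 nM to 30000 nM.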

Compound 4, half-maximal effective concentration: > 34400 nM
Compound 4: only a limit was reported; the forecaster's own chance of this, stated with the estimate: 10%; middle value at least 3.8-fold (0.58 log units) from the limit.
By their numbers in this assay, from the lowest: compound 3; then compounds 1 and 2 (each within the scatter of the next). At a limit, above all of these: compound 4.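

Compound 4 is reported only as a limit: the limit of > 34400 nM in this assay, at which 1 of the 4 values shown sits. The position on the sulfonyl sulfur therefore responds strongly to this change, with an at least 8.3-fold higher number from compound 3 to compound 4 (0.92 log units; beyond the scatter), so the benzyl group does not stand in for pentafluorophenyl here. The other comparisons are an at least 2.0-fold higher number from compound 2 to compound 4 (0.30 log units; that floor lies within the scatter) and an at least 2.1-fold higher number from compound 1 to compound 4 (0.33 log units; beyond the scatter), and only the second of these clears the scatter.

From the compounds shown here alone, how far the true number of compound 4 lies past its limit stays open. So does whether an amine or a longer chain on the sulfonyl sulfur would give a measurable number.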